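A few compounds are considered here, and "the series" means these few. Any claim that something is new, unique, unknown or untested is made for them only; others in the source may bear on it.

Compound 3 `CC(C(=O)NCc1ccc(C(F)(F)F)nc1-c1ccc(F)c(Cl)c1)c1ccc(NS(C)(=O)=O)c(F)c1` gives the lowest number of the three measured in an assay on CHO cells for antagonist activity at transient receptor potential cation channel subfamily V member 1 (Homo sapiens), read by FLIPR (on this read-out higher numbers stand for weaker inhibition and lower numbers for stronger inhibition), at 0.2 nM. Compound 2 `CC(C(=O)NCc1ccc(C(F)(F)F)nc1-c1ccc(C(C)(C)C)cc1)c1ccc(NS(C)(=O)=O)c(F)c1` comes nearest at 0.5 nM, and compound 1 `CC(C(=O)NCc1ccc(C(F)(F)F)nc1-c1ccccc1)c1ccc(NS(C)(=O)=O)c(F)c1` is furthest at 6.4 nM. Compound 4 `CC(C(=O)NCc1ccc(C(F)(F)F)nc1-c1ccoc1)c1ccc(NS(C)(=O)=O)c(F)c1` carries furan-3-yl in place of 3-chloro-4-fluorophenyl on an aromatic carbon. The bearing steps are a 32-fold lower number from compound 1 to compound 3 (1.51 log units; beyond the scatter), a 13-fold lower number from compound 1 to compound 2 (1.11 log units; beyond the scatter) and a 2.5-fold lower number from compound 2 to compound 3 (0.40 log units; beyond the scatter): both substituted phenyl groups gave large gains over the unsubstituted phenyl of compound 1, which sits as the weakest of the set. Furan-3-yl has no counterpart among the measured compounds; it carries fewer heavy atoms than either substituted phenyl and resembles compound 1 in lacking a halogen or tert-butyl group. A loss is therefore expected, of about a 40-fold higher number from compound 3 to compound 4 (1.60 log units; beyond the scatter). For compound 4 in this assay, the estimated value is 8 nM, within a range of 2 nM to 40 nM.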

Compound 4, inhibition constant: 1.4 nM
The estimate for compound 4 lay 5.7-fold (0.76 log units) above the measured number, outside the stated range (below it).
By their numbers in this assay, from the lowest: compound 3; then compound 2; then compound 4; then compound 1.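

In this assay, a gain over phenyl at this position, next to the ring nitrogen, needs neither a halogen nor tert-butyl: furan-3-yl gives a 4.6-fold lower number from compound 1 to compound 4 (0.66 log units; beyond the scatter), with only 5 heavy atoms. The same ring still trails both substituted phenyl groups, with a 7.0-fold higher number from compound 3 to compound 4 (0.85 log units; beyond the scatter) and a 2.8-fold higher number from compound 2 to compound 4 (0.45 log units; beyond the scatter), so the substituted phenyl groups keep the lead among these four compounds. Nothing available gives a reason for these steps.

As far as these compounds go, whether a thiophene or pyridine ring behaves like furan-3-yl here remains open. So does the effect of a saturated ring such as cyclohexyl or of an amine such as morpholine at this position.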